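This account rests on a few compounds, and the source may have more. Where it says the series, first, only, none or still open, it means among the compounds named here.

In an assay on Huh-7 cells for agonist activity at Bile acid receptor (Homo sapiens), read by a luciferase reporter (on this read-out lower numbers stand for an effect already at smaller amounts and higher numbers for an effect only at larger amounts of compound), compound 1 `CC(C)c1onc(-c2c(Cl)cccc2Cl)c1COc1ccc(-c2nc3cc(C(=O)O)ccc3n2C)cc1` gives 25.8 nM, whereas compound 2 `CC(=O)N1CCC(n2c(-c3ccc(OCc4c(-c5c(Cl)cccc5Cl)noc4C(C)C)cc3)nc3ccc(C(=O)O)cc32)CC1` gives 1430 nM, the highest of the two numbers and a gap beyond the scatter. Compound 3 `CCCC(CCC)n1c(-c2ccc(OCc3c(-c4c(Cl)cccc4Cl)noc3C(C)C)cc2)nc2ccc(C(=O)O)cc21` differs from compound 2 in one place: 1-propylbutyl in place of 1-acetylpiperidin-4-yl on an aromatic nitrogen. Only these two values offer guidance, and neither tells how the entering group will read. The expected step of a 4.8-fold lower number from compound 2 to compound 3 (0.68 log units; beyond the scatter) in this assay points to a lower number, beyond the scatter, though with wide uncertainty. Compound 3 is estimated at 300 nM, with a range from 60 nM to 1500 nM.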

Compound 3, half-maximal effective concentration: 1.8 nM
For compound 3 the middle estimate is 170-fold (2.22 log units) above the measured one; the whole stated range lies above it.
By their numbers in this assay, from the lowest: compound 3; then compound 1; then compound 2.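

In this assay the group on this aromatic nitrogen moves the read-out strongly: 1-propylbutyl in place of 1-acetylpiperidin-4-yl gives a 790-fold lower number from compound 2 to compound 3 (2.90 log units; beyond the scatter) on a single change, so an open branched all-carbon group reads far better here than the acetylated ring. That change removes the ring, the ring nitrogen and the carbonyl together, and this one step cannot separate them. Nothing available explains the size of the step. On these data alone, it remains open how a free piperidin-4-yl amine, a cyclohexyl ring or a shorter 1-ethylpropyl chain would read at this position.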